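The source may hold more compounds than are shown below. What is called first, only, known or untested is meant among the compounds shown, and "the series" means these compounds.

Compound 1, `COc1ccc(/C=N/c2c(C)n(C)n(-c3ccccc3)c2=O)cc1`: 977000000 nM
Compound 2, `Cc1c(/N=C/c2cccc(O)c2)c(=O)n(-c2ccccc2)n1C`: 372000000 nM

Both compounds were tested in a functional assay on DLD-1 cells (Homo sapiens) for cytotoxicity, read by MTT assay, with a stated time of 72 h; on this read-out lower numbers stand for stronger inhibition and higher numbers for weaker inhibition. In this assay compound 1 gives 977000000 nM, while compound 2 gives 372000000 nM, the lowest of the two numbers. Within the data shown here, the single measured step, a 2.6-fold lower number from compound 1 to compound 2 (0.42 log units; beyond the scatter), comes from 3-hydroxyphenyl in place of 4-methoxyphenyl on a carbon with a double bond to nitrogen.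

Compound 3, `Cc1c(/N=C/c2cccc([N+](=O)[O-])c2)c(=O)n(-c2ccccc2)n1C`, is the next step from compound 2: nitro in place of hydroxy on an aromatic carbon. Among the measured compounds shown here, no measured step exchanges hydroxy for nitro. For the measured compounds named here, the one step available touches the same ring of the shared core but swaps a different pair of groups, so it bears on this change only loosely: it shows that altering the group on that ring moved the number, but modestly. With nothing closer to lean on, the expectation for compound 3 is a number near that of compound 2, with no step beyond the scatter in either direction. Compound 3 is therefore estimated at 400000000 nM, with a range from 150000000 nM to 1000000000 nM. This estimate means a 1.1-fold higher number from compound 2 to compound 3 (0.03 log units; within the scatter).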

Compound 3, half-maximal inhibitory concentration: 490000000 nM
Compound 3: middle estimate off by 1.2-fold (0.09 log units), on the low side; low and high end bracket the measured number.
By their numbers in this assay, from the lowest: compounds 2, 3 and 1 (each within the scatter of the next, the first and the last beyond it).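

Compounds 2 and 3 keep their group on the same aromatic carbon, meta to a large group, so this pair shows what the group alone does there, which the earlier step could not show because it changed both the group and its place. In this assay, exchanging hydroxy, with 1 heavy atom and a hydrogen-bond donor, for nitro, with 3 heavy atoms and no hydrogen-bond donor, gives a 1.3-fold higher number from compound 2 to compound 3 (0.12 log units; within the scatter), so these two quite different groups cannot be told apart on this carbon, and the donor of compound 2 is not needed to reach its number. The data give no measured property that would explain this result.

On these data alone, whether any group on this carbon can move the number beyond the scatter remains open, and an amine, a carboxylic acid or a longer chain such as propoxy would test that. A methoxy group on this same carbon would also help, since it would separate the effect of the group from the effect of its place in the step from compound 1 to compound 2.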